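The compounds below may be only part of what the source reports. "The series", "measured", "known", "first", "only" and "open" are said of these compounds alone.

Compound 3 `COc1nc2ccc(Br)cc2cc1C(c1ccccc1)n1cc(CCCO)nn1` carries a 3-hydroxypropyl group on the triazole of the shared core. In an ADME assay on PC-3 cells (Homo sapiens) for cytotoxicity, read by sulforhodamine B assay, with a stated time of 48 h, tested at 10 uM (a higher number here means more inhibition at the concentration tested (going by the name of the read-out), a lower number less inhibition), compound 3 gives 14.7%. Among the measured compounds shown here, on the numbers so far it stands between the other two, though all three lie within the usual scatter of each other: compound 1 `COc1nc2ccc(Br)cc2cc1C(c1ccccc1)n1cc(C2CC2)nn1` gives 22.6% and compound 2 `COc1nc2ccc(Br)cc2cc1C(c1ccccc1)n1cc(-c2ccccc2F)nn1` gives 13.4%, so that a number 7.9 percentage points lower from compound 1 to compound 3 (within the scatter) and a number 1.3 percentage points higher from compound 2 to compound 3 (within the scatter), and also a number 9.2 percentage points lower from compound 1 to compound 2 (within the scatter), are all steps of no weight beyond the scatter.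

Compound 4 `COc1nc2ccc(Br)cc2cc1C(c1ccccc1)n1cc(CO)nn1` differs from compound 3 by hydroxy in place of 2-hydroxyethyl on a saturated chain carbon bound to an aromatic carbon, that is, the chain on the triazole is shortened so that only a hydroxymethyl group remains. The steps that touch the same position, from compound 1 and from compound 2 to compound 3, each changed the group on that aromatic carbon and each stayed within the scatter, even when a cyclopropyl or a 2-fluorophenyl group was swapped for the 3-hydroxypropyl chain. Nothing in these data suggests the shortened hydroxyalkyl chain should behave otherwise, so the expected step of a number 0.3 percentage points higher from compound 3 to compound 4 (within the scatter) is none beyond the scatter. Compound 4 is therefore expected to give about 15% in this assay, with a range of 4% to 28%.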

Compound 4, a percentage reported as inhibition, at one concentration (the size of the read-out at that concentration, not a potency): 4.65%
Estimate against measurement, compound 4: 10.4 percentage points above; the range from low to high includes it.
By their numbers in this assay, from the lowest: compounds 4, 2, 3 and 1 (each within the scatter of the next, the first and the last beyond it).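

In this assay, this position had so far shown no step beyond the scatter, but shortening the chain does produce one, a modest change (with a number 10.1 percentage points lower from compound 3 to compound 4 (beyond the scatter)), even though 3-hydroxypropyl and hydroxymethyl have the same count of hydrogen-bond donors and acceptors. The hydroxymethyl group also separates from cyclopropyl (with a number 18 percentage points lower from compound 1 to compound 4 (beyond the scatter)), again modestly, while the comparison with 2-fluorophenyl stays inside the scatter (with a number 8.8 percentage points lower from compound 2 to compound 4 (within the scatter)), so the position is not shown to be fully indifferent, and only part of the set can be told apart. Nothing measured here accounts for the drop that comes with the shorter chain.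

The compounds shown leave open whether the number follows chain length step by step, which a 2-hydroxyethyl group or a longer chain would test, and whether the hydroxy group itself matters, which a plain propyl chain, an amine or a carboxylic acid would test. They also leave open whether the same shortening would give a step of this size on a different core, or at a different concentration, since all of these values come from one concentration and none is a potency.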